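The compounds below may be only part of what the source reports. "The series", "measured", "known", "first", "only" and "open" are said of these compounds alone.

Measured compounds:
- Compound 1, `COCc1nc(-c2ccc(Cl)cc2)sc1C(=O)OC`: 388000 nM
- Compound 2, `CNC(=O)c1sc(-c2ccc(Cl)cc2)nc1COC`: 50800 nM
- Compound 3, `CNC(=O)c1sc(-c2ccc(Cl)cc2)nc1C=O`: "not determined" (no result reported)

In an ADME assay on BHK15 cells (Mesocricetus auratus) for inhibition, read by XTT assay, with a stated time of 36 h (a lower number here means a stronger inhibitor of growth, a higher number a weaker inhibitor of growth), compound 1 gives 388000 nM and compound 2 gives 50800 nM. The two differ by methoxy in place of methylamino on a carbonyl carbon, and the step of a 7.6-fold higher number from compound 2 to compound 1 (0.88 log units; beyond the scatter) in this assay. For compound 3 this assay returned no result. Its core differs from that of compound 2 by formyl in place of methoxymethyl on an aromatic carbon.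

Compound 4, `COC(=O)c1sc(-c2ccc(Cl)cc2)nc1C=O`, has not yet been tested in this assay. It differs from compound 3 by methoxy in place of methylamino on a carbonyl carbon. Within the data shown here, this is the same change as that from compound 2 to compound 1, on the same kind of place, and one might expect a step of similar size in this assay; but as compound 3 has no number, no such step can be laid beside the earlier one. The expectation for compound 4 therefore rests on compound 1, whose value of 388000 nM it is expected to come close to, since both carry the methoxycarbonyl group. Compound 4 is estimated at 300000 nM, between 60000 nM and 1000000 nM.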

Compound 4, concentration for 50% growth inhibition: 36400 nM
Beside the measured number, compound 4's estimate is 8.2-fold (0.92 log units) above it, and the stated range ends above it.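

In this assay there is an 11-fold lower number from compound 1 to compound 4 (1.03 log units; beyond the scatter), with formyl in place of methoxymethyl on an aromatic carbon, so this change counts for much on the core that carries methoxycarbonyl. Among these compounds, it does not show that the change carries to the core that carries methylcarbamoyl: the matching step from compound 2 to compound 3 cannot be read, and neither can the step from compound 3 to compound 4, since compound 3 has no result, which leaves a 7.6-fold higher number from compound 2 to compound 1 (0.88 log units; beyond the scatter) as the only reading of methoxy in place of methylamino, on one core alone. Nothing shown here explains the size of either step.

The compounds shown leave open how a hydroxymethyl or a carboxylic acid on that aromatic carbon would compare with formyl and methoxymethyl. They also leave open how an ethoxy or a dimethylamino group on the carbonyl carbon would read against methoxy and methylamino.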